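Cytotoxicity notes: phenyl extension on the acyl chain

This account rests on a few compounds, and the source may have more. Where it says the series, first, only, none or still open, it means among the compounds named here.

Measured compounds:
compound 1, `CC1=NN(C(=O)c2ccc(C)cc2)C(c2ccccc2O)C1`, 11300 nM
compound 2, `CCC(=O)N1N=C(C)CC1c1cc(Br)ccc1O`, "not active" (no number reported)

In a functional assay on HepG2 cells (Homo sapiens) for cytotoxicity, read by MTT assay, with a stated time of 48 h (on this read-out higher numbers stand for weaker inhibition and lower numbers for stronger inhibition), compound 1 gives 11300 nM. Within the data shown here, compound 2 is reported only as "not active" (no number reported) in this assay, so no single number places it among the measured compounds, and compound 1 stands as the only compound with a figure. Among the measured compounds shown here, no step between measured compounds is available that would bear on the change considered here.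

Compound 3, `CC1=NN(C(=O)CCc2ccccc2)C(c2cc(Br)ccc2O)C1`, is yet to be measured. It differs from compound 2 by phenyl in place of hydrogen on a saturated chain carbon, two bonds along the chain from a carbonyl carbon. Compound 2 and compound 3 share everything else. With compound 2 reported as "not active" (no number reported), the expectation for compound 3 rests on that report and on the lone figure of compound 1, and a weak reading is expected, with a fair chance that this assay again gives no number for it. Compound 3 is estimated at 30000 nM, within 8000 nM to 120000 nM.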

Compound 3, half-maximal inhibitory concentration: 17900 nM
Compound 3: middle estimate off by 1.7-fold (0.22 log units), on the high side, and the stated range covers the measured number.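

In this assay compound 2 is reported only as not active and compound 3 gives 17900 nM so no step can be read between them. No measured evidence bears on this result. The compounds shown leave open how large any change from hydrogen to phenyl on this chain is.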